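Replacing the indanylamine on the piperidine of a triazolylindole

This account rests on a few compounds, and the source may have more. Where it says the series, first, only, none or still open, it means among the compounds named here.

Compound 2, `c1ccc2c(c1)CCC2NC1CCN(CCCc2c[nH]c3ccc(-n4cnnc4)cc23)CC1`: 8.9 nM
Compound 1, `O[C@H]1Cc2ccccc2C1NC1CCN(CCCc2c[nH]c3ccc(-n4cnnc4)cc23)CC1`: 37 nM

In an assay on CHO cells for displacement of a labelled ligand from 5-hydroxytryptamine receptor 1D (Homo sapiens) (on this read-out lower numbers stand for stronger inhibition and higher numbers for weaker inhibition), compound 2 gives the lower of the two numbers; its nearest neighbour is compound 1, separated by a 4.2-fold lower number from compound 1 to compound 2 (0.62 log units; beyond the scatter). Compound 3, `CN(Cc1ccccc1)CC1CCN(CCCc2c[nH]c3ccc(-n4cnnc4)cc23)CC1`, differs from compound 2 by (benzyl(methyl)amino)methyl in place of (2,3-dihydro-1H-inden-1-yl)amino on a saturated ring carbon. Among the measured compounds shown here, the only measured step, a 4.2-fold lower number from compound 1 to compound 2 (0.62 log units; beyond the scatter), concerns a hydroxy removed from the group that now leaves entirely, so it bears only loosely on this change. A modest loss is expected for compound 3, a 2.8-fold higher number from compound 2 to compound 3 (0.45 log units; beyond the scatter), giving an estimate of 25 nM with a range of 6 nM to 100 nM.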

Compound 3, half-maximal inhibitory concentration: 0.9 nM
Compound 3: the middle estimate sits 28-fold (1.44 log units) above what was measured; measured number below the stated range.
By their numbers in this assay, from the lowest: compound 3; then compound 2; then compound 1.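

At this saturated ring carbon the ring of (2,3-dihydro-1H-inden-1-yl)amino is not needed in this assay: (benzyl(methyl)amino)methyl, with no hydrogen-bond donor, gives a 9.9-fold lower number from compound 2 to compound 3 (1.00 log units; beyond the scatter). Measured against the hydroxy-bearing group, the same replacement gives a 41-fold lower number from compound 1 to compound 3 (1.61 log units; beyond the scatter). Nothing available here accounts for these gains.

The compounds shown do not separate the contributions of the methyl on the nitrogen, the added methylene and the opened ring. From the compounds shown here alone, whether an amide or an ether in place of the amine would keep this number also remains open.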